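From anilino to piperidin-1-yl on the shared core

A few compounds are considered here, and "the series" means these few. Any claim that something is new, unique, unknown or untested is made for them only; others in the source may bear on it.

Within the data shown here, in a functional assay on ECa-109 cells for inhibition, with ECa-109 cell line (Homo sapiens) as the target, read by sulforhodamine B assay (a lower number here means a stronger inhibitor, a higher number a weaker inhibitor), compound 2 `O=C1C=C(Nc2ccccc2)C(=O)c2c1nc1n2[C@H]2OC[C@@H](O)[C@H]2OC1` gives 4970 nM, the only actual number available so far. Compound 1 `CCCN(CCC)C1=CC(=O)c2nc3n(c2C1=O)[C@H]1OC[C@@H](O)[C@H]1OC3` gives > 16000 nM, which is a limit of the assay and not a number. Among the measured compounds shown here, the single measured step, an at least 3.2-fold lower number from compound 1 to compound 2 (0.50 log units; beyond the scatter), put anilino in place of dipropylamino on a double-bonded ring carbon, and it lies beyond the scatter. Compound 3 `O=C1C=C(N2CCCCC2)C(=O)c2c1nc1n2[C@H]2OC[C@@H](O)[C@H]2OC1` changes that same place again: piperidin-1-yl in place of anilino on a double-bonded ring carbon. This removes the anilino group that separates the two measured compounds. Piperidin-1-yl, like the dipropylamino of compound 1, carries no aromatic ring, so part of an at least 3.2-fold lower number from compound 1 to compound 2 (0.50 log units; beyond the scatter) may well be given back. One step is thin evidence, so this expectation is loose. The expected change is a 2.0-fold higher number from compound 2 to compound 3 (0.30 log units; within the scatter), towards a weaker inhibitor. Compound 3 is estimated at 10000 nM, with an expected range from 4000 nM to 25000 nM.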

Compound 3, half-maximal inhibitory concentration: > 8000 nM
Compound 3 ended at the assay's limit (the forecaster's own chance of this, stated with the estimate: 35%); the middle value does not contradict the limit.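

Putting piperidin-1-yl on this double-bonded ring carbon gives an at least 1.6-fold higher number from compound 2 to compound 3 (0.20 log units; that floor lies within the scatter), so this step alone does not establish a loss beyond the scatter, although the true gap could be larger. The result for compound 3 is a limit of the assay, not a number: the limit of > 8000 nM in this assay, at which 1 of the 3 values shown sits.

Even so, a second amine without an aromatic ring now ends at a limit, and among these three compounds only compound 2, with anilino, gives an actual number.

The two limits leave the step from compound 1 to compound 3 unreadable. Anilino differs from piperidin-1-yl in both its aromatic ring and its hydrogen-bond donor, so it remains open which of these matters, and a cyclohexylamino group at this place could help separate the two.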